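The source may hold more compounds than are shown below. What is called first, only, known or untested is meant among the compounds shown, and "the series" means these compounds.

In a functional assay on HepG2 cells (Homo sapiens) for antiproliferative activity, read by MTT assay, with a stated time of 72 h (a higher number here means a weaker inhibitor, a lower number a stronger inhibitor), compound 3 (`COc1ccc(-c2cnc3scc(C(=O)NNC(C)=O)n23)cc1`) gives 11800 nM, the lowest number of the three measured, compared with compound 2 (`CCCC(=O)NNC(=O)c1csc2ncc(-c3ccc(C)cc3)n12`) at 26800 nM and compound 1 (`CC(=O)NNC(=O)c1csc2ncc(-c3ccc(C)cc3)n12`) at 63600 nM. Compound 4 (`CCCC(=O)NNC(=O)c1csc2ncc(-c3ccc(OC)cc3)n12`) departs from compound 3 by ethyl in place of hydrogen on a saturated chain carbon bound to a carbonyl carbon, with ethyl in place of hydrogen on a saturated chain carbon bound to a carbonyl carbon. The same change has been measured once, as a 2.4-fold lower number from compound 1 to compound 2 (0.38 log units; beyond the scatter), a modest step beyond the scatter. The other measured step, a 5.4-fold lower number from compound 1 to compound 3 (0.73 log units; beyond the scatter), is methoxy in place of methyl, and it shows nothing directly about the ethyl change. From the compounds shown here alone, whether the first step carries over to the methoxy compounds is unknown, but a similar modest drop in this assay is expected. The expected step is a 2.1-fold lower number from compound 3 to compound 4 (0.33 log units; beyond the scatter). Compound 4 is estimated at 5500 nM, within a range of 2300 nM to 13000 nM.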

Compound 4, half-maximal inhibitory concentration: 38000 nM
Estimate against measurement, compound 4: 6.9-fold (0.84 log units) below; measured number outside the range, above it.
By their numbers in this assay, from the lowest: compound 3; then compounds 2, 4 and 1 (each within the scatter of the next, the first and the last beyond it).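

In this assay the step from acetyl to propylcarbonyl changes direction with the other substituent, giving a 3.2-fold higher number from compound 3 to compound 4 (0.51 log units; beyond the scatter) on the methoxy side, opposite to the drop seen on the methyl side: the same change on two cores in this assay, a 2.4-fold lower number (0.38 log units; beyond the scatter) from compound 1 to compound 2 and a 3.2-fold higher number (0.51 log units; beyond the scatter) from compound 3 to compound 4, 7.6-fold (0.88 log units) apart, beyond the scatter of two such steps Methoxy in place of methyl, read with the propylcarbonyl chain, gives only a 1.4-fold higher number from compound 2 to compound 4 (0.15 log units; within the scatter), so the earlier gain does not carry over: the same change on two cores in this assay, a 5.4-fold lower number (0.73 log units; beyond the scatter) from compound 1 to compound 3 and a 1.4-fold higher number (0.15 log units; within the scatter) from compound 2 to compound 4, 7.6-fold (0.88 log units) apart, beyond the scatter of two such steps The two places therefore do not act independently in these four compounds.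

Still open, from the compounds shown here alone, is whether a longer chain, or an amine at the end of the chain, would follow the methyl or the methoxy compounds.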